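Restoring an aryl group on the amine side chain

A few compounds are considered here, and "the series" means these few. Any claim that something is new, unique, unknown or untested is made for them only; others in the source may bear on it.

Measured compounds:
Compound 1, `COc1cc(Oc2cccc(Nc3ccccc3)c2)cc(OC)c1CNCc1ccc(F)cc1`: 2650 nM
Compound 2, `COc1cc(Oc2cccc(Nc3ccccc3)c2)cc(OC)c1CNCCNC(C)=O`: 6010 nM

In a functional assay on DLD-1 cells (Homo sapiens) for inhibition, read by MTT assay, with a stated time of 72 h (a lower number here means a stronger inhibitor, a higher number a weaker inhibitor), compound 2 gives 6010 nM, the highest of the two numbers; its nearest neighbour is compound 1, which gives 2650 nM in this assay. Within the data shown here, the one measured step, a 2.3-fold higher number from compound 1 to compound 2 (0.36 log units; beyond the scatter), shows that swapping an aromatic group on the chain for a short acetamide-bearing chain gave a modestly weaker inhibitor.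

Compound 3, `COc1ccc(CCCNCc2c(OC)cc(Oc3cccc(Nc4ccccc4)c3)cc2OC)cc1`, reverses that direction in spirit: 4-methoxybenzyl in place of acetamido on a saturated chain carbon, two bonds along the chain from an amine nitrogen. The chain carrying the amine again ends in an aromatic ring, and the hydrogen-bond donor of the acetamido group is gone.

Among the measured compounds shown here, the only step bearing on this is the one from compound 1 to compound 2, which was modest and beyond the scatter. Reintroducing an aryl terminus is therefore expected to move the number back toward that of compound 1, giving for compound 3 an estimated step of a 2.1-fold lower number from compound 2 to compound 3 (0.33 log units; beyond the scatter). Compound 3 is thus expected at about 2800 nM in this assay, within a range of 1400 nM to 5600 nM.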

Compound 3, half-maximal inhibitory concentration: 2540 nM
Compound 3: middle estimate off by 1.1-fold (0.04 log units), on the high side; the range from low to high includes it.
By their numbers in this assay, from the lowest: compounds 3 and 1 (each within the scatter of the next); then compound 2.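

In this assay, the change at this position, on a saturated chain carbon two bonds along the chain from an amine nitrogen, now proves to be reversible: placing 4-methoxybenzyl where acetamido stood gives a 2.4-fold lower number from compound 2 to compound 3 (0.37 log units; beyond the scatter) and so recovers the modest step lost with the acetamide. The aromatic chain end also need not be the same one, since 2-(4-methoxyphenyl)ethyl in place of 4-fluorophenyl gives a 1.0-fold lower number from compound 1 to compound 3 (0.02 log units; within the scatter) and leaves compound 1 and compound 3 indistinguishable in this assay, so that among these three compounds only compound 2, with its 2-acetamidoethyl chain, stands apart, and none goes against that reading. Nothing at hand gives a measured reason for this result.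

The compounds shown leave open whether the amide itself or merely the absence of an aromatic ring separates compound 2 from the other two, a question that a plain 3-phenylpropyl chain or a 2-methoxyethyl chain would bear on. They also leave open how a terminal carboxylic acid or a primary amine at the chain end would read in this assay.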